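Swapping Methoxypyridine for Fluoropyrimidine in a P2X7 Series

The compounds below may be only part of what the source reports. "The series", "measured", "known", "first", "only" and "open" are said of these compounds alone.

In a functional assay on HEK293 cells for antagonist activity at P2X purinoceptor 7 (Homo sapiens) (on this read-out higher numbers stand for weaker inhibition and lower numbers for stronger inhibition), compound 3 `COc1ccc(-c2ccc(Cl)c(C(=O)NCC3(O)CCCCCC3)c2)nc1` gives 213 nM, the highest number of the three measured and therefore the weakest inhibitor among them. By comparison, compound 1 `Cc1cnc(-c2ccc(Cl)c(C(=O)NCC3(O)CCCCCC3)c2)cn1` gives 22 nM and compound 2 `O=C(NCC1(O)CCCCCC1)c1cc(-c2ccc(CO)cn2)ccc1Cl` gives 17 nM. The change to compound 4 `O=C(NCC1(O)CCCCCC1)c1cc(-c2ncc(F)cn2)ccc1Cl` is 5-fluoropyrimidin-2-yl in place of 5-methoxypyridin-2-yl on an aromatic carbon. Within the data shown here, two measured steps bear on this, since each removed the 5-methoxypyridin-2-yl group: a 9.7-fold higher number from compound 1 to compound 3 (0.99 log units; beyond the scatter) and a 13-fold higher number from compound 2 to compound 3 (1.10 log units; beyond the scatter), both beyond the scatter and both in the direction of weaker inhibition. Reversing that exchange, a clearly lower number is expected for compound 4, a 5.3-fold lower number from compound 3 to compound 4 (0.73 log units; beyond the scatter). The estimate for compound 4 in this assay is 40 nM, with a range from 10 nM to 160 nM.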

Compound 4, half-maximal inhibitory concentration: 16 nM
For compound 4 the middle estimate is 2.5-fold (0.40 log units) above the measured one; the range from low to high includes it.
By their numbers in this assay, from the lowest: compounds 4, 2 and 1 (each within the scatter of the next); then compound 3.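

Replacing 5-methoxypyridin-2-yl with 5-fluoropyrimidin-2-yl gives a large step (a 13-fold lower number from compound 3 to compound 4 (1.12 log units; beyond the scatter)), showing that this aromatic carbon also accepts a ring with 2 hetero atoms. Compound 4 cannot be told apart from the other two compounds (a 1.1-fold lower number from compound 2 to compound 4 (0.03 log units; within the scatter); a 1.4-fold lower number from compound 1 to compound 4 (0.14 log units; within the scatter)), so three different groups give similar inhibition and only the 5-methoxypyridin-2-yl group of compound 3 stands apart. No measurement given here accounts for that difference. Still open, as far as these compounds go, is how a 5-methoxypyrimidin-2-yl group would compare with these groups. From the compounds shown here alone, the effect of an amine or a carboxylic acid in place of the fluorine is also open.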